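A Benzyl Swap on an Inactive Amide

The source may hold more compounds than are shown below. What is called first, only, known or untested is meant among the compounds shown, and "the series" means these compounds.

Three related compounds have been tested in a functional assay (QGY7701 cells, Homo sapiens) for inhibition, read by MTT assay, with a stated time of 48 h; on this read-out higher numbers stand for weaker inhibition and lower numbers for stronger inhibition. Among the measured compounds shown here, compound 1 (`COc1ccc(CNC(=O)/C=C/c2coc3cc(O)ccc3c2=O)cc1`) gives 10000 nM, the only actual number among them. Compound 2 (`COc1ccc2c(=O)c(/C=C/C(=O)Nc3cc(C)ccc3C)coc2c1`) reads > 100000 nM, which is a limit of the assay and not a number. Compound 3 (`COc1ccc(NC(=O)/C=C/c2coc3cc(O)ccc3c2=O)cc1`) reads > 100000 nM, also a limit. Compound 2 therefore stands at the limit of > 100000 nM in this assay, at which 2 of the 3 values shown sit, and its true value is not known.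

Compound 4 (`COc1ccc2c(=O)c(/C=C/C(=O)NCc3ccc(C)cc3)coc2c1`) has 4-methylbenzyl in place of 2,5-dimethylphenyl on an amide-type nitrogen. For the measured compounds named here, no measured pair isolates this change, so any step is an expectation only. Stronger inhibition than for compound 2 is expected in this assay, because compound 1 gives 10000 nM and resembles compound 4 at that nitrogen. The expected change is an at least 3.3-fold lower number from compound 2 to compound 4 (0.52 log units; beyond the scatter), a moderate step toward stronger inhibition, though compound 4 could still end at the limit. For compound 4 the estimated value is 30000 nM, with an expected range from 7000 nM to 100000 nM.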

Compound 4, half-maximal inhibitory concentration: 10200 nM
The estimate for compound 4 lay 2.9-fold (0.47 log units) above the measured number; the measured number falls inside the stated range.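

In this assay, among the compounds shown here, putting 4-methylbenzyl in place of 2,5-dimethylphenyl on the amide-type nitrogen gives an at least 9.8-fold lower number from compound 2 to compound 4 (0.99 log units; beyond the scatter), the first step that can be read at this position. The two groups match in heavy atoms, in their single carbon ring and in hydrogen-bond donors and acceptors, so this position responds to how the same atoms are joined and not only to what they are. Compound 2 stays a limit and not a number, so the step has only a lower bound and its full size is unknown: the limit of > 100000 nM in this assay, at which 2 of the 4 values shown sit.

The change alters the group's link to the nitrogen and its methyl pattern together, and the compounds shown do not separate the two. Going by these compounds, how an unsubstituted benzyl or a longer chain such as 2-phenylethyl would read on this nitrogen also remains open.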